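From 4-chlorophenyl to 3-iodophenyl on the shared core

The compounds below may be only part of what the source reports. "The series", "measured", "known", "first", "only" and "open" are said of these compounds alone.

Of the compounds shown here, two with a shared core have been measured in a functional assay on MCF7 cells (Homo sapiens) for antiproliferative activity, read by MTT assay, with a stated time of 48 h; on this read-out lower numbers stand for stronger inhibition and higher numbers for weaker inhibition. Compound 1 (`Cc1ccc2nc(NC(c3cn(-c4ccccc4)nc3-c3cccc(Cl)c3)c3c(O)ccc4ccccc34)sc2c1`) gives 49700 nM. Compound 2 (`COc1ccc2nc(NC(c3cn(-c4ccccc4)nc3-c3ccc(Cl)cc3)c3c(O)ccc4ccccc34)sc2c1`) gives 23700 nM, the lower of the two numbers, and the gap between them lies beyond the scatter. These two differ in more than one place, so their gap cannot be read as the result of any single change. Compound 3 (`COc1ccc2nc(NC(c3cn(-c4ccccc4)nc3-c3cccc(I)c3)c3c(O)ccc4ccccc34)sc2c1`) has not yet been measured. It carries 3-iodophenyl in place of 4-chlorophenyl on an aromatic carbon of the five-membered aromatic ring with 2 nitrogen: 3-iodophenyl in place of 4-chlorophenyl on an aromatic carbon. Within the data shown here, no measured pair shows this change alone, so only a small move towards a higher number is expected in this assay, with the estimated step of a 1.3-fold higher number from compound 2 to compound 3 (0.10 log units; within the scatter) staying within the scatter. Compound 3 is expected at 30000 nM, within an estimated range of 11000 nM to 80000 nM.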

Compound 3, half-maximal inhibitory concentration: 20000 nM
For compound 3 the middle estimate is 1.5-fold (0.18 log units) above the measured one; the measured number falls inside the stated range.
By their numbers in this assay, from the lowest: compounds 3 and 2 (each within the scatter of the next); then compound 1.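

In this assay, among these compounds, 3-iodophenyl in place of 4-chlorophenyl on an aromatic carbon of the five-membered aromatic ring with 2 nitrogen gives a 1.2-fold lower number from compound 2 to compound 3 (0.07 log units; within the scatter), the first reading of a single change at this position, so the assay does not separate these two groups here. The step alters the halogen and where it stands on the phenyl ring together, and the two contributions cannot be told apart from this pair. No available evidence bears on this result.

The compounds shown leave open whether the iodine or its ring position would matter alone, as they include no pair that isolates either one. They also leave open how this assay would read a phenyl ring carrying an amine or a carboxylic acid at this position.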